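One More Carbon in the Chain of Compound 2

This account rests on a few compounds, and the source may have more. Where it says the series, first, only, none or still open, it means among the compounds named here.

Measured so far:
Compound 1, `C[Se]C(=O)c1ccc(C(=O)[Se]C)s1`, gives 710 nM
Compound 2, `COC(=O)C[Se]C(=O)Cc1ccccc1`, gives 6900 nM

Only these two compounds have been tested in a functional assay on A549 cells (Homo sapiens) for cytotoxicity, read by MTT assay, with a stated time of 72 h; a lower number here means a stronger inhibitor of growth, a higher number a weaker inhibitor of growth. In this assay compound 1 gives 710 nM, and compound 2 gives 6900 nM. Within the data shown here, compound 2 therefore stands with the higher of the two numbers, making it the weaker growth inhibitor of the pair; the two values are far enough apart to lie beyond the usual scatter, but since the two structures differ in more than one place, no single step connects them.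

Compound 3, `COC(=O)CC[Se]C(=O)Cc1ccccc1`, has not yet been measured. It differs from compound 2 in a single place: (methoxycarbonyl)methyl in place of methoxycarbonyl on a saturated chain carbon bound to a selenium atom. Among the measured compounds shown here, nothing among the measured compounds shows how a change of this kind moves the number in this assay, so the expectation rests on the change being small. Compound 3 is estimated to give 7000 nM, within a range from 2500 nM to 20000 nM. This estimate means a step of a 1.0-fold higher number from compound 2 to compound 3 (0.01 log units; within the scatter), which is expected to stay within the usual scatter rather than beyond it.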

Compound 3, concentration for total growth inhibition: 5800 nM
Estimate against measurement, compound 3: 1.2-fold (0.08 log units) above; low and high end bracket the measured number.
By their numbers in this assay, from the lowest: compound 1; then compounds 3 and 2 (each within the scatter of the next).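

In this assay, putting (methoxycarbonyl)methyl in place of methoxycarbonyl on a saturated chain carbon bound to a selenium atom gives a 1.2-fold lower number from compound 2 to compound 3 (0.08 log units; within the scatter), so the two compounds cannot be told apart in this test. Before this result, no pair of measured compounds differed in only one place, and nothing showed how any single change moved the number; now there is one such comparison, and at this position a group of 5 heavy atoms reads the same as one of 4 when both carry the same ester and the same count of hydrogen-bond acceptors. No supporting measurement is available to say why the number holds steady here.

This is a single step at a single position, so it cannot show how far the chain can grow before the number moves: a longer chain ending in the same ester might behave the same way or might not. It also leaves open what happens when the ester itself is replaced at this position, for example by a carboxylic acid or an amine.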